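This account rests on a few compounds, and the source may have more. Where it says the series, first, only, none or still open, it means among the compounds named here.

Of the compounds shown here, two built on one shared core have been tested in a functional assay on A2780 cells (Homo sapiens) for inhibition; a higher number here means a weaker inhibitor, a lower number a stronger inhibitor. Compound 1 (`CC(C(=O)Nc1cc(C2CC2)[nH]n1)c1ccc(N2C(=O)CCC2C)cc1`) gives 6400 nM, and compound 2 (`CC(C(=O)Nc1cc(C2CC2)[nH]n1)c1ccc(-n2ccnc2O)cc1`) gives 6980 nM. Compound 2 therefore stands level with compound 1, and the two numbers cannot be told apart. Compound 3 (`CC(C(=O)Nc1cc(C2CC2)[nH]n1)c1ccc(-n2cnnc2O)cc1`) has not yet been measured. The change leading to it from compound 2 is a group of 6 heavy atoms (2 carbon, 3 nitrogen, 1 oxygen; one five-membered aromatic ring with 3 hetero atoms) in place of a group of 6 heavy atoms (3 carbon, 2 nitrogen, 1 oxygen; one five-membered aromatic ring with 2 hetero atoms), on an aromatic carbon, on an aromatic carbon of a six-membered aromatic ring of carbon only, para to a large group. Among the measured compounds shown here, only one measured step bears on this change: a 1.1-fold higher number from compound 1 to compound 2 (0.04 log units; within the scatter). That step also exchanged the group on an aromatic carbon, and it stayed within the scatter. For the measured compounds named here, a single step is thin evidence, and no measured compound yet carries the five-membered aromatic ring with 3 hetero atoms. Even so, no step beyond the scatter is expected in this assay. The expected step is a 1.0-fold higher number from compound 2 to compound 3 (0.00 log units; within the scatter). For compound 3 the estimated value is 7000 nM, with an expected range from 3000 nM to 15000 nM.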

Compound 3, half-maximal inhibitory concentration: 8390 nM
Estimate against measurement, compound 3: 1.2-fold (0.08 log units) below; low and high end bracket the measured number.
By their numbers in this assay, from the lowest: compounds 1, 2 and 3 (each within the scatter of the next).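

In this assay, the five-membered aromatic ring with 3 hetero atoms takes the place of the one with 2 hetero atoms, on an aromatic carbon of a six-membered aromatic ring of carbon only, para to a large group, and the result is a 1.2-fold higher number from compound 2 to compound 3 (0.08 log units; within the scatter); an exchange between two aromatic rings of equal heavy-atom count thus cannot be told apart at this position. Set against the five-membered non-aromatic ring with 1 hetero atom, the same ring gives a 1.3-fold higher number from compound 1 to compound 3 (0.12 log units; within the scatter), so all three groups tested at this position lie within the scatter of one another, and the first measured step no longer stands alone. No measurement shown here speaks to why these groups read alike.

On these data alone, all three compounds carry a five-membered ring at this position on an otherwise unchanged core, so it remains open whether a group of another kind there, such as an amine, a carboxylic acid or a longer chain, would step beyond the scatter. Nor do these compounds show how much the ring contributes at all, since none has a plain hydrogen in its place.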